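Cytotoxicity notes on amine-nitrogen substituent swaps in one series

A few compounds are considered here, and "the series" means these few. Any claim that something is new, unique, unknown or untested is made for them only; others in the source may bear on it.

Compound 1 `CCOC(=O)NC(=O)NC1=CS(=O)(=O)O[C@@]12[C@@H](CO[Si](C)(C)C(C)(C)C)O[C@@H](n1cc(C)c(=O)n(C)c1=O)[C@@H]2O[Si](C)(C)C(C)(C)C`: 14000 nM
Compound 2 `COC(=O)CNC1=CS(=O)(=O)O[C@@]12[C@@H](CO[Si](C)(C)C(C)(C)C)O[C@@H](n1cc(C)c(=O)n(C)c1=O)[C@@H]2O[Si](C)(C)C(C)(C)C`: 160000 nM

Going by the values given here, in a functional assay on HEL cells (Homo sapiens) (a lower number here means that less compound is tolerated, a higher number that more compound is tolerated), compound 2 gives the higher of the two numbers so far; its nearest neighbour is compound 1, and the single measured step is an 11-fold higher number from compound 1 to compound 2 (1.06 log units; beyond the scatter). Compound 3 `CCNC(=O)NC1=CS(=O)(=O)O[C@@]12[C@@H](CO[Si](C)(C)C(C)(C)C)O[C@@H](n1cc(C)c(=O)n(C)c1=O)[C@@H]2O[Si](C)(C)C(C)(C)C` is the next member to be tested. The change from compound 2 is ethylcarbamoyl in place of (methoxycarbonyl)methyl on an amine nitrogen. Among the compounds with values here, no measured step covers this exact swap, so an 11-fold higher number from compound 1 to compound 2 (1.06 log units; beyond the scatter) is the only guide: compound 1 also carries a carbamoyl-type group on the amine nitrogen, and compound 3 is therefore expected to move back toward compound 1 rather than stay at the level of compound 2. The expected step is a 5.3-fold lower number from compound 2 to compound 3 (0.73 log units; beyond the scatter), a lower number with considerable uncertainty. For compound 3 the estimate in this assay is 30000 nM, within a range of 10000 nM to 100000 nM.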

Compound 3, half-maximal cytotoxic concentration: 10000 nM
The estimate for compound 3 lay 3.0-fold (0.48 log units) above the measured number; measured number inside the range.
By their numbers in this assay, from the lowest: compounds 3 and 1 (each within the scatter of the next); then compound 2.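

In this assay, the step of a 16-fold lower number from compound 2 to compound 3 (1.20 log units; beyond the scatter) shows that the large gap first seen with compound 1 is not confined to the (ethoxycarbonyl)carbamoyl group, since ethylcarbamoyl on this amine nitrogen also stands well apart from (methoxycarbonyl)methyl. The step of a 1.4-fold lower number from compound 1 to compound 3 (0.15 log units; within the scatter) lies within the scatter, so exchanging ethoxycarbonyl for ethyl on the amide-type nitrogen does not separate these two carbamoyl-type compounds in this read-out. No supporting data on hand explain why compound 2 stands apart from the other two compounds.

The compounds shown leave open whether a carbonyl on the amine nitrogen is enough to give the level of compound 1 and compound 3, which an acetyl group there would test. From the compounds shown here alone, it also remains open how a carboxylic acid in place of the methyl ester of the (methoxycarbonyl)methyl group would compare with compound 2.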